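From a Dihydroxypropyl Chain to a Chlorobenzyl Group

The source may hold more compounds than are shown below. What is called first, only, known or untested is meant among the compounds shown, and "the series" means these compounds.

Compound 1 `Nc1nc(O)c2c(n1)n(C1OC(CO)[C@@H](O)[C@H]1O)c(=O)n2CC(O)CO` was tested in a functional assay on the whole organism (B cells) with Mus musculus as the target (a lower number here means a smaller maximal response, a higher number a larger maximal response), and gives 136%. Two further compounds were measured in the same way. Compound 2 `C=CCn1c(=O)n([C@@H]2O[C@H](CO)[C@H]3OC(C)(CCC(=O)NC)O[C@H]32)c2nc(N)nc(O)c21` gives 9%, and compound 3 `C=CCn1c(=O)n([C@H]2CO[C@@H](CO)C2)c2nc(N)nc(O)c21` gives 10%. Among these three numbers the value of compound 1 is the highest; the nearest to it is the value of compound 3, and the furthest is the value of compound 2, both far below it and each by a margin well beyond the usual scatter. Compounds 2 and 3 differ from compound 1 in more than one place, so the data do not tie their low responses to any single change.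

Compound 4 `Nc1nc(O)c2c(n1)n(C1OC(CO)[C@@H](O)[C@H]1O)c(=O)n2Cc1ccc(Cl)cc1` has not yet been measured. It differs from compound 1 in one place: 4-chlorophenyl in place of 1,2-dihydroxyethyl on a saturated chain carbon bound to an aromatic nitrogen. Among the compounds with values here, no pair of measured compounds isolates this change. Still, because compound 2 gives 9% and compound 3 gives 10%, every departure from compound 1 seen so far has ended low, and a downward step is expected here too, though with wide uncertainty. The step from compound 1 to compound 4 is expected to be a number 56 percentage points lower from compound 1 to compound 4 (beyond the scatter). Compound 4 is therefore estimated at 80%, with a range from 20% to 140%.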

Compound 4, largest response reached (reported as maximal response), in percent of the reference or control that the assay uses: 15%
Beside the measured number, compound 4's estimate is 65 percentage points above it, outside the stated range (below it).
By their numbers in this assay, from the lowest: compounds 2, 3 and 4 (each within the scatter of the next); then compound 1.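

In this assay, within the data shown here, exchanging 2,3-dihydroxypropyl for 4-chlorobenzyl, with the rest of the structure unchanged, gives a step of a number 121 percentage points lower from compound 1 to compound 4 (beyond the scatter), and this is the first change that can be read on its own. Among these compounds, the low responses of the earlier compounds could not be tied to any one place, whereas this pair shows that a single exchange on a saturated chain carbon bound to an aromatic nitrogen is enough to remove most of the response seen with compound 1. No measurement shown here explains why this exchange has so large an effect.

From the compounds shown here alone, the exchange removes the two hydroxyl groups and brings in the 4-chlorophenyl ring in one move, so it remains open whether the drop follows from what leaves, from what enters, or from both. A propyl chain without hydroxyl groups and a benzyl group without the chlorine would separate these two parts of the change, while a single hydroxyl group or a carboxylic acid on the chain would test how much of the original 2,3-dihydroxypropyl group is needed.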